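Working notes: aryl exchange on the saturated ring carbon

The source may report more compounds than this note shows. Statements on the series, on what has been measured and on what is new or still open speak of the compounds shown alone.

Compound 1 `CCCCCCCCCCCCCCCCCCNC(=O)[C@H]1CSC(CCCCCCCCCCCC)N1` and compound 2 `CCCCCCCCCCCCCCCCCCNC(=O)[C@H]1CSC(c2c[nH]c3ccccc23)N1` share one core and differ only in the group carried on a saturated ring carbon. In a functional assay on TSU-Pr1 cells for antiproliferative activity against TSU (Homo sapiens), read by sulforhodamine B assay (on this read-out higher numbers stand for weaker inhibition and lower numbers for stronger inhibition), compound 1 gives 10700 nM, while compound 2 gives 4400 nM. Going by the values given here, the only measured step in the set is a 2.4-fold lower number from compound 1 to compound 2 (0.39 log units; beyond the scatter), and on these two numbers compound 2 stands lowest, with compound 1 as its sole neighbour.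

Compound 3 `CCCCCCCCCCCCCCCCCCNC(=O)[C@H]1CSC(c2cccnc2)N1` has not yet been measured. Relative to compound 2 the change is pyridin-3-yl in place of 1H-indol-3-yl on a saturated ring carbon. Among the compounds with values here, no measured step exchanges one aromatic group for another at this place; the one step available, a 2.4-fold lower number from compound 1 to compound 2 (0.39 log units; beyond the scatter), bears on it only indirectly, showing a modest gain when an aromatic group replaced the dodecyl chain there. Since both compound 2 and compound 3 carry an aromatic group at that carbon, a small step at most is expected, and with the smaller group and the loss of the donor a slightly higher number seems more likely than a lower one. The expected step is a 1.5-fold higher number from compound 2 to compound 3 (0.17 log units; within the scatter). Compound 3 is therefore estimated at 6500 nM, within 2500 nM to 17000 nM.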

Compound 3, half-maximal inhibitory concentration: 7800 nM
Beside the measured number, compound 3's estimate is 1.2-fold (0.08 log units) below it; the range from low to high includes it.
By their numbers in this assay, from the lowest: compounds 2, 3 and 1 (each within the scatter of the next, the first and the last beyond it).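

Going by these compounds alone, at this saturated ring carbon, the first exchange of one aromatic group for another gives, in this assay, a 1.8-fold higher number from compound 2 to compound 3 (0.25 log units; within the scatter), so pyridin-3-yl and 1H-indol-3-yl cannot be told apart on this read-out, even though the exchange removes a ring and swaps the hydrogen-bond donor for an acceptor. The exchange of the dodecyl chain for pyridin-3-yl gives a 1.4-fold lower number from compound 1 to compound 3 (0.14 log units; within the scatter), whereas the exchange for 1H-indol-3-yl gave a 2.4-fold lower number from compound 1 to compound 2 (0.39 log units; beyond the scatter), so the separation from the dodecyl compound that lies beyond the scatter is not shared by both aromatic groups and cannot be claimed for aromatic groups in general at this carbon. Nothing on hand explains how these groups act at this position.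

The compounds shown leave open whether a phenyl or naphthalen-2-yl group at this carbon would stand beyond the scatter from the 1H-indol-3-yl compound. They also leave open whether a shorter chain such as hexyl, or a chain ending in a carboxylic acid or an amine, would differ from dodecyl here.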